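Amide variation on the shared core: pyrrolidinyl for butylamino

The source may report more compounds than this note shows. Statements on the series, on what has been measured and on what is new or still open speak of the compounds shown alone.

Two compounds of the series carry a measurement in a functional assay on the whole organism (strain Wistar) for inhibition, with Rattus norvegicus as the target, read by paw edema, with stated times of 30 min and 3 h, at a dose of 100 mg/kg by the oral route; a lower number here means less inhibition, a higher number more inhibition at the dose given (going by the name of the read-out). Compound 1 `COc1cc(C(=O)N2CCCC2)nn1-c1ccccc1` gives 29.2% in this assay. Compound 2 `CCCCNC(=O)c1cc(OCCCC)n(-c2ccccc2)n1` gives 43.3% in this assay, the higher of the two numbers; the gap down to compound 1 lies beyond the scatter of the measurement. Compound 3 `CCCCOc1cc(C(=O)N2CCCC2)nn1-c1ccccc1` is not yet measured. It differs from compound 2 in one place: pyrrolidin-1-yl in place of butylamino on a carbonyl carbon. Compound 3 also shares its amide with compound 1 and its ether with compound 2, so the two measured numbers bracket it from both sides without fixing which change drives the gap. Among the compounds with values here, no step between measured compounds addresses this amide exchange alone, so the expected step of a number 6.3 percentage points lower from compound 2 to compound 3 (within the scatter) is small and likely within the scatter, if anything slightly downward. Compound 3 is estimated at 37% in this assay, with a range from 22% to 52%.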

Compound 3, a percentage reported as inhibition, in the whole organism at one dose (the size of the read-out at that dose, not a potency): 17.6%
Compound 3: middle estimate off by 19.4 percentage points, on the high side, and the stated range ends above it.
By their numbers in this assay, from the lowest: compound 3; then compound 1; then compound 2.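

In this assay, the amide exchange can now be read on its own: pyrrolidin-1-yl in place of butylamino on a carbonyl carbon gives a number 25.7 percentage points lower from compound 2 to compound 3 (beyond the scatter), as the amide hydrogen leaves and a ring enters. The ether can also be read alone: on the pyrrolidin-1-yl amide, propyl in place of hydrogen on a saturated chain carbon bound to an oxygen on an aromatic ring gives a number 11.6 percentage points lower from compound 1 to compound 3 (beyond the scatter), so the longer ether brings no gain on this amide. Both steps run downward to compound 3, and the butylamino amide is so far the only amide that gives a higher number with the butyl ether.

An N-methyl-N-butylamino amide would separate the loss of the amide hydrogen from the entry of a ring, while a methoxy ether on the butylamino amide would test whether the ether step holds there too. No measurement at hand accounts for either step.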